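Sulfonamide series: tolerated concentration, compound 1 to compound 4

The compounds below may be only part of what the source reports. "The series", "measured", "known", "first", "only" and "open" are said of these compounds alone.

Working notes on three measured sulfonamides and one that awaits measurement. The read-out is an ADME assay on HEK293 cells (Homo sapiens) for cytotoxicity, read by resazurin assay, with a stated time of 48 h; a lower number here means that less compound is tolerated, a higher number that more compound is tolerated.

Compound 1 `O=S(=O)(Nc1ccc(-c2nc3ccccc3o2)cc1)c1cccs1` carries thiophen-2-yl on the sulfonyl sulfur. In this assay compound 1 reaches only the limit > 100000 nM, which is a limit of the assay and not a number. Compound 1 therefore stands at the limit of > 100000 nM in this assay, at which 1 of the 3 values shown sits, and nothing more is known of it in this assay. Compound 2 `O=S(=O)(Nc1ccc(-c2nc3ccccc3o2)cc1)c1ccc(F)c(C(F)(F)F)c1` gives 82000 nM in this assay. Compound 3 `O=S(=O)(Nc1ccc2oc(-c3ccccc3)nc2c1)c1ccc(Cl)c(Cl)c1`, with a differently placed sulfonamide on the shared core, gives 71000 nM in this assay.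

Compound 4 `O=S(=O)(Nc1ccc(-c2nc3ccccc3o2)cc1)c1cccc(Cl)c1` is the next member. Its difference from compound 1 is 3-chlorophenyl in place of thiophen-2-yl on a sulfonyl sulfur.

Among the measured compounds shown here, no step between measured compounds is available, so the size of the change from thiophen-2-yl to 3-chlorophenyl has to be expected rather than read. The expectation is a small step, within or barely beyond the scatter, toward a somewhat lower tolerated concentration, because compound 2 gives 82000 nM and compound 3 gives 71000 nM with halogenated phenyl on the sulfonyl sulfur. For compound 4 the estimated value in this assay is 80000 nM, between 40000 nM and 150000 nM. The estimated step is an at least 1.2-fold lower number from compound 1 to compound 4 (0.09 log units; that floor lies within the scatter).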

Compound 4, half-maximal cytotoxic concentration: > 100000 nM
Compound 4 gave a limit, no number (the forecaster's own chance of this, stated with the estimate: 40%); middle value at least 1.2-fold (0.09 log units) from the limit.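

In this assay, compound 1 and compound 4 each reach only a limit of the assay and not a number, so no step between them can be read: the limit of > 100000 nM in this assay, at which 2 of the 4 values shown sit.

The compounds shown leave open whether 3-chlorophenyl in place of thiophen-2-yl on a sulfonyl sulfur changes the tolerated concentration at all, and by how much.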